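Heteroaryl swap at the aminomethyl position: cytotoxicity notes

The source may hold more compounds than are shown below. What is called first, only, known or untested is meant among the compounds shown, and "the series" means these compounds.

Measured compounds, with their readings in an ADME assay on cells (Homo sapiens) for cytotoxicity, read by polymerase chain reaction, with a stated time of 3 days; on this read-out lower numbers stand for higher toxicity in this test and higher numbers for lower toxicity in this test:
compound 1, `Cc1nc(NCC2CC2)nc(N[C@@H]2C[C@H](CO)[C@@H](O)[C@H]2O)c1-c1nc2ccccc2s1`, gives 8000 nM
compound 2, `Cc1nc(Nc2nccs2)nc(N[C@@H]2C[C@H](CO)[C@@H](O)[C@H]2O)c1-c1nc2ccccc2s1`, gives 15000 nM
compound 3, `Cc1nc(NCc2nccs2)nc(N[C@@H]2C[C@H](CO)[C@@H](O)[C@H]2O)c1-c1nc2ccccc2s1`, gives 23000 nM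

Compound 3 has the highest number of the three: against compound 2 the gap is a 1.5-fold higher number from compound 2 to compound 3 (0.19 log units; within the scatter), while against compound 1 it is a 2.9-fold higher number from compound 1 to compound 3 (0.46 log units; beyond the scatter). Compound 4, `Cc1nc(NCc2ccncc2)nc(N[C@@H]2C[C@H](CO)[C@@H](O)[C@H]2O)c1-c1nc2ccccc2s1`, differs from compound 3 only by pyridin-4-yl in place of 1,3-thiazol-2-yl on a saturated chain carbon bound to a nitrogen on an aromatic ring. Going by the values given here, the steps that bear on this position are a 2.9-fold higher number from compound 1 to compound 3 (0.46 log units; beyond the scatter) and a 1.5-fold higher number from compound 2 to compound 3 (0.19 log units; within the scatter), both modest; exchanging one small aromatic ring for another at this place has moved this assay by little. For compound 4 no step beyond the scatter is expected, no change at the digits printed from compound 3 to compound 4 (within the scatter), so compound 4 is estimated at 23000 nM, within 10000 nM to 50000 nM.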

Compound 4, half-maximal cytotoxic concentration: 7000 nM
For compound 4 the middle estimate is 3.3-fold (0.52 log units) above the measured one; the whole stated range lies above it.
By their numbers in this assay, from the lowest: compounds 4, 1, 2 and 3 (each within the scatter of the next, the first and the last beyond it).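

In this assay, going by these compounds alone, this place proves sensitive to the identity of the ring, contrary to what the earlier compounds suggested: pyridin-4-yl in place of 1,3-thiazol-2-yl gives a 3.3-fold lower number from compound 3 to compound 4 (0.52 log units; beyond the scatter). The (pyridin-4-yl)methyl group also separates from 1,3-thiazol-2-yl on the nitrogen, with a 2.1-fold lower number from compound 2 to compound 4 (0.33 log units; beyond the scatter), whereas the cyclopropyl comparison gives a 1.1-fold lower number from compound 1 to compound 4 (0.06 log units; within the scatter), so that pair cannot be told apart. No available data explain the effect of this swap. Open, going by these compounds, is whether phenyl or pyridin-2-yl at the same place would read with compound 3 or with compound 4.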